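From bromo to fluoro in a cytotoxicity test

A few compounds are considered here, and "the series" means these few. Any claim that something is new, unique, unknown or untested is made for them only; others in the source may bear on it.

In an ADME assay on MT4 cells (Homo sapiens) for cytotoxicity, read by MTT assay, with a stated time of 4 days (on this read-out lower numbers stand for higher toxicity in this test and higher numbers for lower toxicity in this test), compound 1 `O=C(c1ccccc1)c1cc(Br)ccc1OCCn1ccc(=O)[nH]c1=O` reads > 301000 nM, which is a limit of the assay and not a number. Compound 2 `Cc1cc(C)cc(C(=O)c2cc(Br)ccc2OCCn2ccc(=O)[nH]c2=O)c1` reads > 282000 nM, which is also a limit. Going by the values given here, the one measured step, a step that the two limits leave unreadable from compound 1 to compound 2, changes another part of the molecule, and it offers no size to carry over.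

Compound 3 `O=C(c1ccccc1)c1cc(F)ccc1OCCn1ccc(=O)[nH]c1=O` keeps the rest of compound 1 and carries a single change: fluoro in place of bromo on an aromatic carbon. Fluoro takes the place of bromo on an aromatic carbon. With only limits to go on, no step beyond the scatter is expected in this assay, in either direction, and a further limit is the likeliest report. The expected size is given by the estimated step that the limit leaves unreadable from compound 1 to compound 3. Compound 3 is expected near 350000 nM, with an estimated range of 150000 nM to 420000 nM.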

Compound 3, half-maximal cytotoxic concentration: > 353000 nM
Compound 3 gave a limit, no number; the forecaster's own chance of this, stated with the estimate: 80%; at least 1.0-fold (0.00 log units) between middle value and limit.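

Compound 1 and compound 3 both gave limits in this assay, not numbers, so the step from compound 1 to compound 3 cannot be read. The compounds shown leave open the concentration at which any of them becomes toxic, and whether swapping bromo for fluoro changes it.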